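Branched alkoxy chain on a diarylpropanoic acid core

A few compounds are considered here, and "the series" means these few. Any claim that something is new, unique, unknown or untested is made for them only; others in the source may bear on it.

Compound 1, `CCCCOc1ccc(C(CC(=O)O)c2ccccc2)cc1`: 1.2 uM
Compound 2, `CCCCCCCOc1ccc(C(CC(=O)O)c2ccccc2)cc1`: 4.26 uM
Compound 3, `C/C=C/COc1ccc(C(CC(=O)O)c2ccccc2)cc1`: 2.71 uM

All three were tested in a functional assay on HEK293 cells for agonist activity at Free fatty acid receptor 1 (Homo sapiens), read by calcium flux; a higher number here means that more compound is needed for the effect, a lower number that less compound is needed. Compound 3 stands second highest of the three numbers; it lies within the scatter of compound 2 and needs more compound than compound 1, a 2.3-fold higher number from compound 1 to compound 3 (0.35 log units; beyond the scatter). Compound 4, `CCC(CC)COc1ccc(C(CC(=O)O)c2ccccc2)cc1`, has not yet been measured. It differs from compound 3 as follows: pentan-3-yl in place of prop-1-en-1-yl on a saturated chain carbon bound to an oxygen on an aromatic ring. Within the data shown here, two measured steps touch the same place, a 2.3-fold higher number from compound 1 to compound 3 (0.35 log units; beyond the scatter) and a 1.6-fold lower number from compound 2 to compound 3 (0.20 log units; within the scatter), and both were modest at most. Adding chain length further out, a 3.6-fold higher number from compound 1 to compound 2 (0.55 log units; beyond the scatter), pushed the number up somewhat. The group entering in compound 4 is larger than the one it replaces, so a small rise is plausible, but every change at this carbon so far has stayed modest. The step for compound 4 is therefore expected to be a 1.2-fold higher number from compound 3 to compound 4 (0.07 log units; within the scatter), within the scatter. The estimate for compound 4 is 3.2 uM, with a range from 1.4 uM to 7.5 uM.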

Compound 4, concentration for half-maximal effect: 0.64 uM
Compound 4: middle estimate off by 5.0-fold (0.70 log units), on the high side; the measured number lies below the stated range.
By their numbers in this assay, from the lowest: compounds 4 and 1 (each within the scatter of the next); then compounds 3 and 2 (each within the scatter of the next).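

In this assay, the step of a 4.2-fold lower number from compound 3 to compound 4 (0.63 log units; beyond the scatter) shows that more carbon at this place does not have to raise the number, as the longer chain of compound 2 had suggested. Branching is what sets compound 4 apart: the step of a 6.7-fold lower number from compound 2 to compound 4 (0.82 log units; beyond the scatter) separates it from the straight chain, while the step of a 1.9-fold lower number from compound 1 to compound 4 (0.27 log units; within the scatter) shows that adding ethyl to the chain of compound 1 gives no change that can be told from scatter. Nothing shown here offers a measured explanation for this behaviour.

On these data alone, it remains open whether a smaller branch such as isopropyl, or a ring such as cyclopentyl, on this same carbon would give a similarly low number. As far as these compounds go, the effect of a hydroxyl or an amine on the branch also remains open.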